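The compounds below may be only part of what the source reports. "The series", "measured", "known", "first", "only" and "open" are said of these compounds alone.

Measured in a functional assay on HeLa cells (Homo sapiens) for inhibition, read by CCK-8 assay, with a stated time of 48 h; a lower number here means a stronger inhibitor, a higher number a weaker inhibitor:

Compound 1, `COc1ccc(C2=NN(C3=NC(c4ccccc4)CS3)C(c3cccc4ccccc34)C2)cc1`, gives 3310 nM.
Compound 2, `Cc1ccc(C2=NN(C3=NC(c4ccccc4)CS3)C(c3ccc4ccccc4c3)C2)cc1`, gives 2460 nM.
Compound 3, `O=C1CSC(N2N=C(c3ccc(Cl)cc3)CC2c2cccc3ccccc23)=N1`, gives 8840 nM.

Compound 2 shows the lowest of the three numbers in this assay. Compound 1 sits closest to it, and the gap between compound 2 and compound 1 lies within the scatter, so the two cannot be told apart. Compound 3 stands furthest from compound 2, and that gap lies beyond the scatter. Compound 3 also differs from compound 2 in more than one place, so its value says nothing about any single change.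

Compound 4, `Brc1ccc(C2=NN(C3=NC(c4ccccc4)CS3)C(c3ccc4ccccc4c3)C2)cc1`, has not been measured. It differs from compound 2 by bromo in place of methyl on an aromatic carbon. For the measured compounds named here, no pair among the measured compounds isolates this exchange, so there is no step to rest on. The shared core and the rest of the molecule stay as in compound 2.

With nothing measured on this change, the expectation for compound 4 in this assay is a step of a 1.0-fold higher number from compound 2 to compound 4 (0.01 log units; within the scatter), not beyond the scatter in either direction. Compound 4 is therefore estimated at 2500 nM, with a range from 1000 nM to 6500 nM.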

Compound 4, half-maximal inhibitory concentration: 4960 nM
Estimate against measurement, compound 4: 2.0-fold (0.30 log units) below, and the stated range covers the measured number.
By their numbers in this assay, from the lowest: compounds 2, 1, 4 and 3 (each within the scatter of the next, the first and the last beyond it).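

In this assay, for the compounds shown here, the change from 4-methylphenyl to 4-bromophenyl gives a 2.0-fold higher number from compound 2 to compound 4 (0.30 log units; within the scatter), the only step so far that isolates a single exchange. On this read-out, methyl and bromo on the aromatic carbon para to a large group cannot be told apart, so this one position accepts either group with the rest of the molecule unchanged, and that single pair is all the finding rests on. No measurement available here offers an explanation for this result.

As far as these compounds go, whether an amine, a carboxylic acid or a longer chain such as n-butyl at this same position would give a step beyond the scatter remains open, as does the reading for the bare phenyl with hydrogen in place of methyl or bromo. Steps involving compound 1 or compound 3 cannot be read, since each differs from compound 2 and compound 4 in more than one place, so the methoxy group of compound 1 and the carbonyl of compound 3 have no separate contribution to report.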